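The compounds below may be only part of what the source reports. "The series", "measured", "known", "first", "only" and "open" are said of these compounds alone.

Of the compounds shown here, three built on one shared core have been tested in an in vitro functional assay on HEK285-7 cells for antagonist activity at prostaglandin D2 receptor 2 (Homo sapiens), read by BRET and beta-arrestin recruitment; a higher number here means a larger maximal response, a lower number a smaller maximal response. Compound 1 `O=C(O)Cc1sc(C(c2ccccc2)c2ccccc2)nc1-c1ccc(F)cc1` reaches 80%. Compound 2 `O=C(O)Cc1sc(C(c2ccccc2)c2ccc(Cl)cc2)nc1-c1ccc(F)cc1` gives 80%; putting chloro in place of hydrogen on an aromatic carbon gave no change at the digits printed from compound 1 to compound 2 (within the scatter). Compound 3 `O=C(O)Cc1sc(C(c2ccc(F)cc2)c2ccc(F)cc2)nc1-c1cccc(F)c1` reaches 80%, level with compound 1 and compound 2 within the scatter of the method, so the three measured compounds sit at one common height.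

Compound 4 `O=C(O)Cc1sc(C(c2ccc(F)cc2)c2ccc(F)cc2)nc1-c1ccccc1` has not yet been measured. It differs from compound 3 in a single spot: hydrogen in place of fluoro on an aromatic carbon. Going by the values given here, only one measured step alters a single substituent on a six-membered aromatic ring of carbon only, and that step is no change at the digits printed from compound 1 to compound 2 (within the scatter). Among the compounds with values here, no measured pair shows what taking a fluoro off such a ring does, so the expectation rests on that one unchanged step and on the flat level of all three measured compounds. Compound 4 is therefore expected to give 80%, within a range from 70% to 90%. The step this estimate means, no change at the digits printed from compound 3 to compound 4 (within the scatter), is expected to stay within the scatter.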

Compound 4, largest response reached (reported as efficacy), in percent of the reference or control that the assay uses: 80%
Estimate against measurement, compound 4: no gap at the digits printed, within the range that was stated.
By their numbers in this assay, from the lowest: compounds 1, 2, 3 and 4 (each within the scatter of the next).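

Going from 3-fluorophenyl to phenyl gives the first direct reading of what taking a fluoro off such a ring does: in this assay the step is no change at the digits printed from compound 3 to compound 4 (within the scatter). Going by these compounds alone, the only earlier single-substituent step put a chloro in place of hydrogen at another place, so this result adds a second site, meta to a large group, where exchanging one substituent for another leaves the reading within the scatter. Nothing available here explains why the maximal response holds steady.

All four compounds carry only hydrogen, fluoro or chloro on their aromatic rings, and all sit at one level, so the limits of this flat behaviour remain unseen. As far as these compounds go, whether an amine, a methoxy group or a longer alkyl chain at this position would shift the maximal response stays open.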